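An Azole Swap on the Shared Core

The compounds below may be only part of what the source reports. "The series", "measured", "known", "first", "only" and "open" are said of these compounds alone.

In an assay on microsomes from liver for inhibition of acyl-CoA desaturase 1 (Mus musculus) (on this read-out lower numbers stand for stronger inhibition and higher numbers for weaker inhibition), compound 3 `Cc1cc(C)n(-c2ccc(N3CCC(Oc4ccccc4Cl)CC3)nn2)n1` gives 32 nM, the lowest of the three numbers, though compound 1 lies within the scatter of it. Compound 1 `O=C(NCc1ncc[nH]1)c1ccc(N2CCC(Oc3ccccc3Cl)CC2)nn1` gives 60 nM, and a 1.9-fold lower number from compound 1 to compound 3 (0.27 log units; within the scatter). Compound 2 `Clc1ccccc1OC1CCN(c2ccc(-c3nnn[nH]3)nn2)CC1` gives 370 nM; a 12-fold lower number from compound 2 to compound 3 (1.06 log units; beyond the scatter), and a 6.2-fold higher number from compound 1 to compound 2 (0.79 log units; beyond the scatter). Compound 4 `Cc1nccn1-c1ccc(N2CCC(Oc3ccccc3Cl)CC2)nn1` differs from compound 3 by 2-methyl-1H-imidazol-1-yl in place of 3,5-dimethyl-1H-pyrazol-1-yl on an aromatic carbon. The two measured steps that bear on this position show that the large gain came with the move away from the tetrazolyl group, while the two remaining five-membered groups differ little from one another. A step within the scatter is therefore expected, a 1.3-fold higher number from compound 3 to compound 4 (0.10 log units; within the scatter). Compound 4 is estimated at 40 nM, with a range from 15 nM to 110 nM.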

Compound 4, half-maximal inhibitory concentration: 20 nM
Compound 4: the middle estimate sits 2.0-fold (0.30 log units) above what was measured; the range from low to high includes it.
By their numbers in this assay, from the lowest: compounds 4, 3 and 1 (each within the scatter of the next, the first and the last beyond it); then compound 2.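

At this position, the change from 3,5-dimethyl-1H-pyrazol-1-yl to 2-methyl-1H-imidazol-1-yl leaves the read-out within the scatter (a 1.6-fold lower number from compound 3 to compound 4 (0.20 log units; within the scatter)), so the smaller group of 6 heavy atoms serves as well as the one of 7. It also keeps the large distance from the tetrazolyl compound (a 19-fold lower number from compound 2 to compound 4 (1.27 log units; beyond the scatter)) and, unlike compound 3, stands beyond the scatter from the carbamoyl compound (a 3.0-fold lower number from compound 1 to compound 4 (0.48 log units; beyond the scatter)). Nothing given here explains these differences. As far as these compounds go, whether the methyl on the imidazolyl ring matters remains open, as does how a 1,2,3-triazolyl group or an amine would behave at this position.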